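Methyl in place of tert-butyl on a carbonyl carbon

This account rests on a few compounds, and the source may have more. Where it says the series, first, only, none or still open, it means among the compounds named here.

Values so far in a toxicity assay on KB cells (Homo sapiens) for cytotoxicity, read by fluorescence, with a stated time of 3 days; a lower number here means that less compound is needed, a higher number that more compound is needed for the effect
- compound 1 `CCCCOC(=O)CNC(=O)[C@H](CSc1ccc([N+](=O)[O-])cc1[N+](=O)[O-])NC(=O)CC[C@H](NC(=O)OCc1ccccc1)C(=O)OCCCC` gives 95.2 uM
- compound 2 `CCCCOC(=O)CNC(=O)[C@H](CSc1ccc([N+](=O)[O-])cc1[N+](=O)[O-])NC(=O)CC[C@H](NC(=O)C(C)(C)C)C(=O)OCCCC` gives 83.4 uM

Compound 2 stands level with compound 1, within the usual scatter of repeat measurements. Compound 3 `CCCCOC(=O)CNC(=O)[C@H](CSc1ccc([N+](=O)[O-])cc1[N+](=O)[O-])NC(=O)CC[C@H](NC(C)=O)C(=O)OCCCC` carries methyl in place of tert-butyl on a carbonyl carbon. Among the measured compounds shown here, only one measured step bears on this change. It also alters a group on a carbonyl carbon, putting tert-butyl in place of benzyloxy, and a 1.1-fold lower number from compound 1 to compound 2 (0.06 log units; within the scatter) stays within the scatter. For the measured compounds named here, that is thin evidence, and no measured compound yet carries methyl there. No step beyond the scatter is therefore expected in this assay for this change. The estimated step is a 1.1-fold higher number from compound 2 to compound 3 (0.03 log units; within the scatter) and so is expected to be negligible. Compound 3 is expected at 90 uM in a range from 45 uM to 180 uM as an estimate.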

Compound 3, concentration for half-maximal effect: > 300 uM
Compound 3: only a limit was reported; the forecaster's own chance of this, stated with the estimate: 25%; at least 3.3-fold (0.52 log units) between middle value and limit.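

In this assay, this place on a carbonyl carbon now proves sensitive to the group it carries. The earlier exchange of benzyloxy for tert-butyl stayed within the scatter, but methyl gives an at least 3.5-fold higher number from compound 2 to compound 3 (0.55 log units; beyond the scatter), and measured against benzyloxy it gives an at least 3.1-fold higher number from compound 1 to compound 3 (0.49 log units; beyond the scatter). The reading for compound 3 is a limit and not a number, so both steps show only a minimum size: the limit of > 300 uM in this assay, at which 1 of the 3 values shown sits.

With only tert-butyl, benzyloxy and methyl shown at this place, it remains open at which group the number starts to climb. An ethyl or isopropyl group on the same carbonyl carbon could stay level with compound 2 or rise as far as compound 3, and the compounds shown do not tell which.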